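A few compounds are considered here, and "the series" means these few. Any claim that something is new, unique, unknown or untested is made for them only; others in the source may bear on it.

Measured so far:
compound 1 `CS(=O)(=O)Nc1ccc([N+](=O)[O-])cc1OCC1CCCCC1` — 1210 nM
compound 2 `CC(C)Oc1cc([N+](=O)[O-])ccc1N(C)S(C)(=O)=O` — 2810 nM

In an assay on SK-BR-3 cells for inhibition of Aromatase (Homo sapiens) (on this read-out higher numbers stand for weaker inhibition and lower numbers for stronger inhibition), compound 2 gives 2810 nM, the higher of the two numbers. Compound 1 gives 1210 nM, a gap beyond the scatter. Compound 3 `CN(c1ccc([N+](=O)[O-])cc1OCC1CCCCC1)S(C)(=O)=O` is not yet measured in this assay; it differs from compound 2 by cyclohexylmethyl in place of isopropyl on an oxygen on an aromatic ring. Going by the values given here, no measured pair shows this change directly. Because compound 1 with cyclohexylmethyl gives 1210 nM, a downward step of moderate size is expected for compound 3, a 1.9-fold lower number from compound 2 to compound 3 (0.27 log units; within the scatter). Compound 3 is estimated at 1500 nM, range 600 nM to 4000 nM.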

Compound 3, half-maximal inhibitory concentration: 960 nM
For compound 3 the middle estimate is 1.6-fold (0.19 log units) above the measured one, within the range that was stated.
By their numbers in this assay, from the lowest: compounds 3 and 1 (each within the scatter of the next); then compound 2.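

In this assay, cyclohexylmethyl in place of isopropyl on an oxygen on an aromatic ring now has a direct pair (a 2.9-fold lower number from compound 2 to compound 3 (0.47 log units; beyond the scatter)), with the sulfonamide nitrogen carrying methyl on both sides. Methyl in place of hydrogen on that nitrogen (a 1.3-fold lower number from compound 1 to compound 3 (0.10 log units; within the scatter)) does not separate the two compounds when cyclohexylmethyl sits on the oxygen. Nothing at hand speaks to a cause for either step.

Open, as far as these compounds go, is whether a longer straight chain or a phenyl ring on that oxygen would match cyclohexylmethyl, and how an amine there would read. Also open, from the compounds shown here alone, is whether the nitrogen methyl stays without effect when isopropyl sits on the oxygen.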